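A few compounds are considered here, and "the series" means these few. Any claim that something is new, unique, unknown or untested is made for them only; others in the source may bear on it.

Measured so far:
- compound 1 `COc1cc(-c2cc3nccc(-c4c[nH]c5ccccc45)n3n2)cc(OC)c1OC`: > 10000 nM
- compound 2 `COc1cc(-c2ccnc3cc(-c4ccc(C)c(C)c4)nn23)cc(OC)c1OC`: 26 nM

Both compounds were tested in a functional assay on MCF7 cells (Homo sapiens) for inhibition, read by CCK-8 assay, with a stated time of 48 h; on this read-out higher numbers stand for weaker inhibition and lower numbers for stronger inhibition. For compound 1, the entry > 10000 nM is a limit and not a number. Within the data shown here, compound 2, at 26 nM, holds the only numerical value so far.

Compound 3 `COc1cc(-c2ccnc3cc(-c4ccc(C(F)(F)F)cc4)nn23)cc(OC)c1OC` keeps the shared core of compound 2 and carries 4-(trifluoromethyl)phenyl in place of 3,4-dimethylphenyl on an aromatic carbon. Among the measured compounds shown here, no measured step covers this change, so the expectation is loose. A loss of inhibition beyond the scatter is expected in this assay, towards higher numbers, starting from compound 2 at 26 nM. The estimated change is a 7.7-fold higher number from compound 2 to compound 3 (0.89 log units; beyond the scatter). For compound 3 the estimate is 200 nM, with an expected range of 30 nM to 3000 nM.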

Compound 3, half-maximal inhibitory concentration: 2440 nM
The estimate for compound 3 lay 12-fold (1.09 log units) below the measured number, within the range that was stated.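

In this assay, exchanging 3,4-dimethylphenyl for 4-(trifluoromethyl)phenyl on the aromatic carbon of the five-membered aromatic ring gives a 94-fold higher number from compound 2 to compound 3 (1.97 log units; beyond the scatter). Both groups are a six-membered aromatic ring of carbon only, with no hydrogen-bond donors or acceptors and no net charge, so at this position the number depends strongly on what that ring carries, even with these counts unchanged. Compound 3 gives a number and not a limit, so the step can be read in full, and the read-out does have a ceiling: the limit of > 10000 nM in this assay, at which 1 of the 3 values shown sits.

The step removes the methyl groups and introduces the trifluoromethyl group at once, so the share of each in the loss cannot be separated. Going by these compounds, how 4-methylphenyl, or a ring carrying an amine, would behave at this position stays open.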